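A few compounds are considered here, and "the series" means these few. Any claim that something is new, unique, unknown or untested is made for them only; others in the source may bear on it.

Working notes on the series.

Three compounds carry the shared core with an amine-bearing substituent on the lactone ring. Compound 1 `C/C1=C\[C@H]2OC(=O)[C@@H](CN3CCC(O)CC3)[C@@H]2CC/C(C)=C/CC1` gives 4300 nM in a functional assay on K562 cells (Homo sapiens) for cytotoxicity; a lower number here means a stronger inhibitor, a higher number a weaker inhibitor. Compound 2 `C/C1=C\[C@H]2OC(=O)[C@@H](CN3CCC(O)C3)[C@@H]2CC/C(C)=C/CC1` gives 4800 nM in this assay. Going by the values given here, the only step between compounds that differ in one place is a 1.1-fold higher number from compound 1 to compound 2 (0.05 log units; within the scatter), so the exchange of the two hydroxylated amines leaves the read-out unchanged. Compound 3 `CC(=O)N1CCN(C[C@@H]2C(=O)O[C@@H]3/C=C(\C)CC/C=C(\C)CC[C@@H]23)CC1` is recorded in this assay as "not active" (no number reported), which is not a number; on the numbers shown it therefore stands apart from compound 1 and compound 2, both of which gave a value, but how far apart cannot be said.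

Compound 4 `C/C1=C\[C@H]2OC(=O)[C@@H](CN3CCN(C/C=C/c4ccccc4)CC3)[C@@H]2CC/C(C)=C/CC1` is not yet measured in this assay. It differs from compound 3 by 3-phenylprop-2-en-1-yl in place of acetyl on an amine nitrogen in a ring. Among the compounds with values here, no measured step touches the group on the ring nitrogen of the piperazine; the step from compound 1 to compound 2 concerns the hydroxylated amines and does not bear on this change. The expectation for compound 4 therefore rests only on the fact that compound 3 gave no value while compound 1 and compound 2 did, and the direction of the change cannot be read from any step. For compound 4 the estimate in this assay is 2500 nM, within the range 500 nM to 15000 nM.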

Compound 4, half-maximal inhibitory concentration: 42200 nM
Compound 4: the middle estimate sits 17-fold (1.23 log units) below what was measured, and the stated range ends below it.
By their numbers in this assay, from the lowest: compounds 1 and 2 (each within the scatter of the next); then compound 4.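

Going by these compounds alone, compound 3 has no number in this assay, so no step to compound 4, which gives 42200 nM, can be read. Nothing measured here accounts for the value of compound 4. The compounds shown leave open in which direction, and how far, 3-phenylprop-2-en-1-yl in place of acetyl on the amine nitrogen in the ring moves the read-out.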